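A few compounds are considered here, and "the series" means these few. Any claim that something is new, unique, unknown or untested is made for them only; others in the source may bear on it.

Measured in a physicochemical assay for solubility, in phosphate buffer; on this read-out higher numbers stand for higher solubility and lower numbers for lower solubility:
- compound 1 `C[C@@H]1CN([C@H](C)CO)C(=O)c2cccc(NC(=O)c3ccncc3)c2O[C@@H]1CN(C)Cc1ccc(Oc2ccccc2)cc1`: 86000 nM
- compound 2 `C[C@@H]1CN([C@@H](C)CO)C(=O)c2cccc(NC(=O)c3ccncc3)c2O[C@@H]1CN(C)Cc1ccc(Oc2ccccc2)cc1`: 87000 nM

On this assay, compound 2 stands level with compound 1, the two numbers lying within the scatter of each other. Compound 3 `C[C@@H]1CN([C@@H](C)CO)C(=O)c2cccc(NC(=O)c3ccncc3)c2O[C@H]1CN(C)Cc1ccc(Oc2ccccc2)cc1` is related to compound 2 by the two compounds have the same atoms and bonds and differ only in configuration as drawn: 1 of 3 stereo elements differ; a stereocentre at a saturated ring carbon is drawn S in compound 2 and R in compound 3. Within the data shown here, the stereocentre concerned sits at a saturated ring carbon, and no measured step tests this centre. Among the measured compounds shown here, the only guide is a change of configuration elsewhere, at a saturated chain carbon, where the data show a 1.0-fold higher number from compound 1 to compound 2 (0.01 log units; within the scatter). That pair offers (the fact that compounds 1 and 2 differ only in the configuration as drawn), and it bears on the new change only indirectly. No shift in either direction can therefore be argued, so the expectation is of no step beyond the scatter, with an estimated 1.0-fold lower number from compound 2 to compound 3 (0.01 log units; within the scatter). For compound 3 the expected value is 85000 nM, with an estimated range from 45000 nM to 150000 nM.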

Compound 3, solubility: 1000 nM
Estimate against measurement, compound 3: 85-fold (1.93 log units) above, outside the stated range (below it).
By their numbers in this assay, from the lowest: compound 3; then compounds 1 and 2 (each within the scatter of the next).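

In this assay, the saturated ring carbon turns out to be a highly sensitive stereocentre: changing it from S to R gives an 87-fold lower number from compound 2 to compound 3 (1.94 log units; beyond the scatter), whereas the saturated chain carbon had given only a 1.0-fold higher number from compound 1 to compound 2 (0.01 log units; within the scatter). Where both of these centres differ, the step reads an 86-fold lower number from compound 1 to compound 3 (1.93 log units; beyond the scatter), but that two-centre comparison cannot separate their contributions. The large single-centre step therefore rests on configuration alone, with no group entering or leaving: the fact that compounds 2 and 3 differ only in the configuration as drawn

The compounds shown leave open how the ring carbon behaves when the chain carbon is drawn R, and whether the third stereo element matters at all. They also do not tell whether an amine or a carboxylic acid in place of the chain hydroxyl would alter the difference between the ring carbon configurations.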